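Dechlorinated sulfonyl group: expectation for compound 3

The source may hold more compounds than are shown below. What is called first, only, known or untested is meant among the compounds shown, and "the series" means these compounds.

Among the measured compounds shown here, the two measured members are compound 1 `O=C1[C@@H](NS(=O)(=O)c2cc3ccc(Cl)nc3s2)CCN1Cc1cc2[nH]cccc-2n1` and compound 2 `O=C1[C@@H](NS(=O)(=O)c2cc3ccnc(Cl)c3s2)CCN1Cc1cc2[nH]cccc-2n1`. For the measured compounds named here, in an assay on isolated protein for inhibition of coagulation factor X (Oryctolagus cuniculus), tested at 1 uM (a higher number here means more inhibition at the concentration tested (going by the name of the read-out), a lower number less inhibition), compound 1 gives 23%; in this assay compound 2 gives 45%, the higher of the two numbers recorded, with compound 1 as its only neighbour. Going by the values given here, the single measured step, a number 22 percentage points higher from compound 1 to compound 2 (beyond the scatter), exchanges one chlorine-bearing group on the sulfonyl sulfur for another chlorine-bearing group.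

Compound 3 `O=C1[C@@H](NS(=O)(=O)c2cc3cccnc3s2)CCN1Cc1cc2[nH]cccc-2n1` differs from compound 2 in the same part of the molecule: a group of 9 heavy atoms (7 carbon, 1 nitrogen, 1 sulfur; one five-membered aromatic ring with 1 hetero atom, one six-membered aromatic ring with 1 hetero atom) in place of a group of 10 heavy atoms (7 carbon, 1 nitrogen, 1 sulfur, 1 chlorine; one five-membered aromatic ring with 1 hetero atom, one six-membered aromatic ring with 1 hetero atom), on a sulfonyl sulfur. The group that enters carries no chlorine, so neither measured compound shows the outcome of this change; the step from compound 1 to compound 2 concerns another arrangement of a chlorine-bearing group and does not settle it. A shift in this assay of a number 15 percentage points lower from compound 2 to compound 3 (beyond the scatter) is expected, downward, with wide uncertainty. Compound 3 is therefore estimated at 30%, with a range from 10% to 55%.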

Compound 3, a percentage reported as inhibition, at one concentration (the size of the read-out at that concentration, not a potency): 44%
Estimate against measurement, compound 3: 14 percentage points below; the range from low to high includes it.
By their numbers in this assay, from the lowest: compound 1; then compounds 3 and 2 (each within the scatter of the next).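

In this assay the chlorine-free group on the sulfonyl sulfur and the chlorine-bearing group of compound 2 read alike (a number 1 percentage points lower from compound 2 to compound 3 (within the scatter)), so at this position inhibition at the tested concentration does not depend on having a chlorine in the group. Hydrogen in place of chloro on an aromatic carbon gives a different outcome (a number 21 percentage points higher from compound 1 to compound 3 (beyond the scatter)), so the same kind of exchange does not act alike on the two chlorine-bearing groups, and the chloro of compound 1 goes with the lower number. Nothing on hand offers a measured reason for this difference.

On these data alone, whether a methyl, a methoxy or an amine on that aromatic carbon would match compound 3 remains open. Readings at a single concentration also leave the potency of compound 2 and compound 3 unresolved.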